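A few compounds are considered here, and "the series" means these few. Any claim that something is new, unique, unknown or untested is made for them only; others in the source may bear on it.

Of the compounds shown here, three have been measured in a functional assay on HEK293 cells for agonist activity at trace amine-associated receptor 1 (Homo sapiens), read by cAMP accumulation, with a stated time of 30 min (a lower number here means a smaller maximal response, a higher number a larger maximal response), so far. Compound 2 `NC1=N[C@@H](c2ccccc2Cl)CO1` gives 100%, the highest of the three numbers. Compound 1 `CCN(C[C@@H]1COC(N)=N1)c1ccccc1` gives 94%, and that number sits within the usual scatter of the value of compound 2, so the two cannot be told apart. Compound 3 `CC(C)N(C[C@H]1COC(N)=N1)c1ccccc1` gives 58%, a number that lies beyond the scatter below the value of compound 2.

The next compound, compound 4 `Cc1ccccc1[C@H]1COC(N)=N1`, has not yet been measured. It differs from compound 2 in a single place: methyl in place of chloro on an aromatic carbon. Going by the values given here, no pair of measured compounds differs by this change alone, so there is no step in this set from which its effect could be read directly. Compounds 1 and 3 differ from compound 2 in more than one place, and their values say nothing specific about the exchange of chloro for methyl.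

With the rest of the structure kept, the step from compound 2 to compound 4 in this assay is expected to be small, with no clear direction, and to stay within the scatter, as a number 10 percentage points lower from compound 2 to compound 4 (within the scatter). Compound 4 is therefore expected to give about 90%, with a range from 65% to 105%.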

Compound 4, largest response reached (Emax), in percent of the reference or control that the assay uses: 78%
Estimate against measurement, compound 4: 12 percentage points above, within the range that was stated.
By their numbers in this assay, from the lowest: compound 3; then compound 4; then compounds 1 and 2 (each within the scatter of the next).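

In this assay, the set now holds its first direct reading at this position, with a number 22 percentage points lower from compound 2 to compound 4 (beyond the scatter) for methyl in place of chloro on an aromatic carbon, ortho to a group of 6 heavy atoms. The earlier compounds shown here could not show this, as none of them forms a pair with another that differs by this change alone, and the step shows that the maximal response is not indifferent to which of the two groups sits here, even though they match in heavy-atom count, in having no hydrogen-bond donors or acceptors and in carrying no net charge. Nothing available here bears on what lies behind the step, so it stands as an observation without an explanation.

The compounds shown carry only chloro and methyl at this place, so a single step cannot tell whether other groups, such as fluoro, methoxy, trifluoromethyl or a nitrile, would keep the response of compound 2 or lose more of it. They also leave open whether the same exchange on another carbon of the aromatic ring would give a step of similar size.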